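The source may hold more compounds than are shown below. What is called first, only, known or untested is meant among the compounds shown, and "the series" means these compounds.

Measured in an ADME assay on J774.1 cells (Mus musculus) for cytotoxicity, with a stated time of 48 h; a higher number here means that more compound is needed for the effect, a lower number that less compound is needed:

compound 1 `COC(=O)C1=C(O)C[C@H](c2ccccn2)N(Cc2ccc(OC)cc2)[C@@H]1c1ccccn1` gives 29.9 uM
compound 2 `Clc1cccc(Cl)c1CO/N=C/C1CCN(CCCc2ccccc2)CC1` gives 28.4 uM
compound 3 `COC(=O)C1C(=O)C(C(=O)OC)[C@H](c2ccccn2)N(Cc2ccccc2)[C@@H]1c1ccccn1` gives 34 uM

Compound 3 carries the highest of the three numbers in this assay, but its gaps to compound 1 and to compound 2 both lie within the scatter, so the three values are read as level with one another. Compound 4 `COC(=O)C1C(=O)C(C(=O)OC)[C@H](c2ccccn2)N(Cc2ccccn2)[C@@H]1c1ccccn1` differs from compound 3 in a single place: pyridin-2-yl in place of phenyl on a saturated chain carbon bound to an amine nitrogen in a ring. Among the compounds with values here, no pair of measured compounds differs in only one place, so no measured step bears on this change. The step from no change at the digits printed from compound 3 to compound 4 (within the scatter) is expected to be none beyond the scatter. For compound 4 the estimated value in this assay is 34 uM, with a range from 17 uM to 68 uM.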

Compound 4, concentration for half-maximal effect: 29.9 uM
Compound 4: middle estimate off by 1.1-fold (0.06 log units), on the high side, within the range that was stated.
By their numbers in this assay, from the lowest: compounds 2, 1, 4 and 3 (each within the scatter of the next).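

In this assay the pyridin-2-yl group in place of phenyl on a saturated chain carbon bound to an amine nitrogen in a ring gives a 1.1-fold lower number from compound 3 to compound 4 (0.06 log units; within the scatter) and is the only single-place step among the compounds shown. At this position, a ring nitrogen and one hydrogen-bond acceptor can therefore enter without a step beyond the scatter. No measurement at hand offers an explanation for this result. Open, from the compounds shown here alone, is whether a carboxylic acid or a saturated amine in place of phenyl at this position would give a step beyond the scatter.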